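The source may report more compounds than this note shows. Statements on the series, on what has been measured and on what is new or still open speak of the compounds shown alone.

Measured so far in a functional assay on HCT-116 cells (Homo sapiens) for cytotoxicity, read by MTT assay, with a stated time of 48 h; a higher number here means a weaker inhibitor of growth, a lower number a stronger inhibitor of growth:
compound 1 `Cc1nc2cc(Cl)c(Cl)cc2[nH]1`: 51000 nM
compound 2 `OC[C@H]1O[C@@H](n2cnc3cc(F)c(F)cc32)[C@H](O)[C@@H]1O`: 67000 nM
compound 3 `Cc1nc2cc(Cl)c(Cl)cc2n1C1CCCC1`: 13000 nM

Compound 3, at 13000 nM, has the lowest number of the three, and both of the others lie beyond the scatter above it. The next compound, compound 4 `CS(=O)(=O)c1nc2cc(Cl)c(Cl)cc2n1C1CCCC1`, keeps compound 3 intact except for one group: methylsulfonyl in place of methyl on an aromatic carbon. That carbon sits between two ring nitrogen atoms, next to the ring atom that bears a cyclopentyl group.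

Going by the values given here, only one measured step changes a single place: a 3.9-fold lower number from compound 1 to compound 3 (0.59 log units; beyond the scatter). This modest step concerns cyclopentyl in place of hydrogen on an aromatic nitrogen, not the group on this carbon. Compound 2 differs from the others in several places, so it offers no clean comparison. Among the compounds with values here, no measurement yet shows what a change at this carbon does, which leaves the direction open. Within the data shown here, the one known step serves only as a rough yardstick for size, so no clear move beyond the scatter is expected as the best guess. The estimate amounts to a 1.1-fold lower number from compound 3 to compound 4 (0.03 log units; within the scatter). For compound 4 the estimated value is 12000 nM, with an expected range from 3500 nM to 40000 nM.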

Compound 4, concentration for 50% growth inhibition: 600 nM
Beside the measured number, compound 4's estimate is 20-fold (1.30 log units) above it; the whole stated range lies above it.
By their numbers in this assay, from the lowest: compound 4; then compound 3; then compounds 1 and 2 (each within the scatter of the next).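

In this assay, the aromatic carbon between two ring nitrogen atoms turns out to be a sensitive place, as methylsulfonyl in place of methyl gives a 22-fold lower number from compound 3 to compound 4 (1.34 log units; beyond the scatter). Going by these compounds alone, this is the first measured change at this carbon, and the step is large, whereas the only earlier single-place step, cyclopentyl in place of hydrogen on an aromatic nitrogen, was modest, at a 3.9-fold lower number from compound 1 to compound 3 (0.59 log units; beyond the scatter). No measurement at hand accounts for the size of the new step.

The compounds shown leave open whether this drop in the number belongs to methylsulfonyl in particular or would also appear with another group on the same carbon, such as an amine, a nitrile or a carboxylic acid. They also leave open whether methylsulfonyl would give a step of similar size with hydrogen instead of cyclopentyl on the aromatic nitrogen, as in the core of compound 1.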